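This account rests on a few compounds, and the source may have more. Where it says the series, first, only, none or still open, it means among the compounds named here.

Two compounds have been measured so far in a functional assay on A549 cells (Homo sapiens) for cytotoxicity, read by MTT assay, with a stated time of 72 h (a lower number here means a stronger inhibitor, a higher number a weaker inhibitor), as follows:
- compound 1 `O=C(/C=C/c1ccc([N+](=O)[O-])cc1)Nc1cc2c(Nc3ccc(F)c(Cl)c3)ncnc2cc1O[C@H]1CCOC1` gives 12000 nM in that test
- compound 2 `O=C(/C=C/c1cccc(Cl)c1Cl)Nc1cc2c(Nc3ccc(F)c(Cl)c3)ncnc2cc1O[C@H]1CCOC1` gives 23200 nM in that test

Compound 2 stands at 23200 nM and compound 1 at 12000 nM so the pair cannot be ranked, as the two values lie within the scatter of each other. Compound 3 `COc1ccc(/C=C/C(=O)Nc2cc3c(Nc4ccc(F)c(Cl)c4)ncnc3cc2O[C@H]2CCOC2)c(OC)c1` comes next. Its difference from compound 2 is 2,4-dimethoxyphenyl in place of 2,3-dichlorophenyl on a double-bonded chain carbon bound to a double-bonded chain carbon with 2,4-dimethoxyphenyl in place of 2,3-dichlorophenyl on a double-bonded chain carbon bound to a double-bonded chain carbon. Within the data shown here, only one measured step bears on this place. That step, a 1.9-fold higher number from compound 1 to compound 2 (0.29 log units; within the scatter) exchanged 4-nitrophenyl for 2,3-dichlorophenyl at the same carbon and stayed within the scatter. This is thin evidence, since 2,4-dimethoxyphenyl has not been measured in any other compound here. No step beyond the scatter is therefore expected in this assay in either direction. For compound 3 the estimate is 17000 nM with an expected range from 6000 nM to 45000 nM as its bounds. This estimate means a 1.4-fold lower number from compound 2 to compound 3 (0.14 log units; within the scatter) as the expected step, within the scatter.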

Compound 3, half-maximal inhibitory concentration: 9350 nM
The estimate for compound 3 lay 1.8-fold (0.26 log units) above the measured number; measured number inside the range.
By their numbers in this assay, from the lowest: compounds 3, 1 and 2 (each within the scatter of the next, the first and the last beyond it).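

In this assay, among these compounds, replacing 2,3-dichlorophenyl with 2,4-dimethoxyphenyl on a double-bonded chain carbon bound to a double-bonded chain carbon gives a 2.5-fold lower number from compound 2 to compound 3 (0.39 log units; beyond the scatter) and so provides the first step at this position to lie beyond the scatter, although only modestly. Among the compounds shown here, this does not set 2,4-dimethoxyphenyl apart from every other group measured here, since the exchange for 4-nitrophenyl gives a 1.3-fold lower number from compound 1 to compound 3 (0.11 log units; within the scatter) and leaves those two compounds unranked, so the position so far separates only compound 2 from compound 3, and compound 1 cannot be placed relative to either. Nothing in the data shown accounts for the step between compound 2 and compound 3.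

The compounds shown leave open whether both methoxy groups are needed for the step, which a phenyl carrying a single methoxy group or no substituent at all would help to settle, and whether a dimethylamino group or a carboxylic acid on the same phenyl would move the number further. They also leave open whether the modest step seen here would hold in any test on other cells.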